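A few compounds are considered here, and "the series" means these few. Any claim that something is new, unique, unknown or untested is made for them only; others in the source may bear on it.

Compound 1: `COc1ccc(S(=O)(=O)Nc2cc(Cl)cc(Cl)c2)cc1N1CCNCC1` — in an assay on isolated protein for binding affinity to 5-hydroxytryptamine receptor 6 (Homo sapiens); a lower number here means a stronger inhibitor, a higher number a weaker inhibitor: 0.631 nM
Compound 2: `COc1ccc(S(=O)(=O)Nc2cc(Cl)cc(Br)c2Cl)cc1N1CCNCC1` — in this assay: 2 nM

Two compounds share one core and differ only in the aromatic ring attached to the sulfonamide nitrogen. Compound 1 gives 0.631 nM in this assay, and compound 2 gives 2 nM. Going by the values given here, the single step measured so far, a 3.2-fold higher number from compound 1 to compound 2 (0.50 log units; beyond the scatter), shows that adding a third halogen to that ring moved the number by a modest amount. On the two numbers available, compound 2 stands as the higher of the two.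

Compound 3, `COc1ccc(S(=O)(=O)Nc2cc(Br)cc(Br)c2F)cc1N1CCNCC1`, takes the same route one step further: 3,5-dibromo-2-fluorophenyl in place of 3-bromo-2,5-dichlorophenyl on a sulfonamide nitrogen. The ring keeps three halogens in the same positions; only their identities are exchanged. Among the compounds with values here, the only step that bears on this change is the one from compound 1 to compound 2, and it was modest. Exchanging halogens while keeping their count and arrangement is expected to move the number less than that, with no clear direction: the estimated step of a 1.3-fold lower number from compound 2 to compound 3 (0.12 log units; within the scatter) should stay within the scatter. Compound 3 is therefore expected to give about 1.5 nM in this assay, plausibly between 0.6 nM and 4 nM.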

Compound 3, inhibition constant: 2.51 nM
Compound 3: middle estimate off by 1.7-fold (0.22 log units), on the low side; measured number inside the range.
By their numbers in this assay, from the lowest: compound 1; then compounds 2 and 3 (each within the scatter of the next).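

In this assay, exchanging one set of halogens for another at this position gives a 1.3-fold higher number from compound 2 to compound 3 (0.10 log units; within the scatter), so on a sulfonamide nitrogen the 3,5-dibromo-2-fluorophenyl and 3-bromo-2,5-dichlorophenyl groups cannot be told apart by this measurement. Going by these compounds alone, the new compound also shows that the earlier step, a 3.2-fold higher number from compound 1 to compound 2 (0.50 log units; beyond the scatter), was not tied to one particular set of halogens: a 4.0-fold higher number from compound 1 to compound 3 (0.60 log units; beyond the scatter) points the same way, and across these three compounds both rings with a third halogen give higher numbers than the 3,5-dichlorophenyl ring of compound 1, with no compound going against this. Nothing available explains why the numbers fall as they do.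

All three rings shown carry only halogens, so it remains open how the number would respond to a plain phenyl ring, or to a ring bearing an amine or a carboxylic acid at this position. From the compounds shown here alone, it is also open whether the small gap between the two rings with three halogens would hold on a different core, since every comparison here rests on the shared core alone.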